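Chloro in place of hydrogen on compound 2

The source may hold more compounds than are shown below. What is called first, only, known or untested is meant among the compounds shown, and "the series" means these compounds.

Measured in a functional assay on K562 cells (Homo sapiens) for antiproliferative activity, read by MTT assay, with a stated time of 48 h; a lower number here means a stronger inhibitor of growth, a higher number a weaker inhibitor of growth:
- Compound 1 `COc1ccc(N(C)c2nc(Cl)nc3c2ncn3Cc2cc(OC)cc(OC)c2)cc1` gives 42000 nM
- Compound 2 `COc1cc(Cn2cnc3c(Cl)ncnc32)cc(OC)c1` gives > 100000 nM, a limit and not a number

Compound 2 has only a limit and no exact value: the limit of > 100000 nM in this assay, at which 1 of the 2 values shown sits. Compound 3 `COc1cc(Cn2cnc3c(Cl)nc(Cl)nc32)cc(OC)c1` carries chloro in place of hydrogen on an aromatic carbon, between two ring nitrogen atoms (chloro in place of hydrogen on an aromatic carbon). Among the compounds with values here, no measured pair shows this change, so only a modest step toward stronger growth inhibition is expected in this assay, and compound 1 at 42000 nM is the only exact value to go by. The expected size is an at least 1.4-fold lower number from compound 2 to compound 3 (0.15 log units; that floor lies within the scatter). Compound 3 is estimated at 70000 nM, with an expected range from 25000 nM to 150000 nM.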

Compound 3, concentration for 50% growth inhibition: 4600 nM
The estimate for compound 3 lay 15-fold (1.18 log units) above the measured number; measured number outside the range, below it.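

In this assay, chloro in place of hydrogen on the aromatic carbon between two ring nitrogen atoms gives an at least 21-fold lower number from compound 2 to compound 3 (1.33 log units; beyond the scatter), so this position responds strongly to the change. That size is only a floor: the limit of > 100000 nM in this assay, at which 1 of the 3 values shown sits. Chloro in place of (4-methoxyphenyl)(methyl)amino on an aromatic carbon gives a 9.1-fold lower number from compound 1 to compound 3 (0.96 log units; beyond the scatter), so that amino group is not needed for growth inhibition at this level.

The compounds shown leave open whether chloro itself matters between the two ring nitrogen atoms, or whether fluoro or an amine there would serve as well.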